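A few compounds are considered here, and "the series" means these few. Any claim that something is new, unique, unknown or untested is made for them only; others in the source may bear on it.

Compound 2, `N#Cc1ccc(Cn2cc(C[C@H](O)COCCOC[C@@H](O)Cc3ccc(-c4ccccc4)cc3)nn2)cc1`, stands at the higher of the two numbers recorded in a functional assay on HCT-116 cells (Homo sapiens) for inhibition, read by MTT assay, with a stated time of 72 h (on this read-out lower numbers stand for stronger inhibition of growth and higher numbers for weaker inhibition of growth), where compound 2 gives 8800 nM; its closest neighbour is compound 1, `O[C@H](COCCOC[C@@H](O)Cc1cn(Cc2ccc3ccccc3c2)nn1)Cc1ccc(-c2ccccc2)cc1`, and in this assay compound 1 gives 8600 nM, a gap too small to count. Within the data shown here, the only measured step, a 1.0-fold higher number from compound 1 to compound 2 (0.01 log units; within the scatter), already shows that exchanging the aromatic group carried on that chain carbon hardly moves the number. Compound 3, `O[C@H](COCCOC[C@@H](O)Cc1cn(-c2ccc3[nH]ccc3c2)nn1)Cc1ccc(-c2ccccc2)cc1`, goes further: 1H-indol-5-yl in place of 4-cyanobenzyl on an aromatic nitrogen. Among the measured compounds shown here, this removes the chain carbon and places a different aromatic group directly on the ring nitrogen, a change for which no measured step exists, so the step from compound 2 to compound 1 is only a loose guide. The expectation is still a step within the scatter, that is a 1.1-fold lower number from compound 2 to compound 3 (0.04 log units; within the scatter). Compound 3 is therefore estimated at 8000 nM, with a likely range from 3000 nM to 25000 nM.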

Compound 3, concentration for 50% growth inhibition: 15500 nM
Compound 3: middle estimate off by 1.9-fold (0.29 log units), on the low side; low and high end bracket the measured number.
By their numbers in this assay, from the lowest: compounds 1, 2 and 3 (each within the scatter of the next).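

Placing 1H-indol-5-yl on the aromatic nitrogen gives a 1.8-fold higher number from compound 2 to compound 3 (0.25 log units; within the scatter) and a 1.8-fold higher number from compound 1 to compound 3 (0.26 log units; within the scatter) when compared with the group carried by compound 1. This position therefore accepts an aromatic group attached directly to the ring nitrogen, with no chain carbon, and a hydrogen-bond donor in place of the acceptor of the nitrile, without a shift that stands clear of the scatter. Nothing available here explains why these three different groups give such closely matched numbers.

The compounds shown leave open whether this position remains as undemanding when it carries a group without an aromatic ring, such as an amine or a carboxylic acid. They also leave open whether a longer chain between the ring nitrogen and the aromatic group would move the number beyond the scatter.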